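The compounds below may be only part of what the source reports. "The series", "measured", "known", "first", "only" and "open" are said of these compounds alone.

Measured so far in an assay on isolated protein for inhibition of Indoleamine 2,3-dioxygenase 1 (Homo sapiens), read by spectrophotometry; on this read-out lower numbers stand for stronger inhibition and higher numbers for weaker inhibition:
compound 1, `COCc1cc2cc(/C(=N\O)Nc3cccc(F)c3)ccc2o1`, gives 7100 nM
compound 2, `COCc1cc2cc(/C(=N\O)Nc3cccc(Cl)c3)ccc2o1`, gives 1000 nM
compound 3, `O/N=C(/Nc1cccc(F)c1)c1ccc2oc(-c3ccccc3)cc2c1`, gives 11000 nM

Compound 2 differs from compound 1 by chloro in place of fluoro on an aromatic carbon, and this change gave a 7.1-fold lower number from compound 1 to compound 2 (0.85 log units; beyond the scatter). Compound 3 differs from compound 1 by phenyl in place of methoxymethyl on an aromatic carbon, which gave a 1.5-fold higher number from compound 1 to compound 3 (0.19 log units; within the scatter). Compound 4, `O/N=C(/Nc1cccc(Cl)c1)c1ccc2oc(-c3ccccc3)cc2c1`, is not yet measured; it differs from compound 3 by chloro in place of fluoro on an aromatic carbon, the same change as that between compound 1 and compound 2, at the same place, carried onto the core of compound 3. With one earlier example of this change and the two cores differing only by a step within the scatter, the step from compound 3 to compound 4 in this assay is estimated to be of similar size, a 5.5-fold lower number from compound 3 to compound 4 (0.74 log units; beyond the scatter), resting on a 7.1-fold lower number from compound 1 to compound 2 (0.85 log units; beyond the scatter). Compound 4 is therefore expected to give about 2000 nM, with an expected range from 800 nM to 5000 nM.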

Compound 4, half-maximal inhibitory concentration: 900 nM
Beside the measured number, compound 4's estimate is 2.2-fold (0.35 log units) above it, and the stated range covers the measured number.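

In this assay, chloro in place of fluoro carries from the core of compound 1 to the core of compound 3, with a 12-fold lower number from compound 3 to compound 4 (1.09 log units; beyond the scatter), and the two steps match in size: the same change on two cores in this assay, a 7.1-fold lower number (0.85 log units; beyond the scatter) from compound 1 to compound 2 and a 12-fold lower number (1.09 log units; beyond the scatter) from compound 3 to compound 4, 1.7-fold (0.24 log units) apart, within the scatter of two such steps. Phenyl in place of methoxymethyl, with chloro present, gives a 1.1-fold lower number from compound 2 to compound 4 (0.05 log units; within the scatter), so on these four compounds the two changes read as independent of each other: the same change on two cores in this assay, a 1.5-fold higher number (0.19 log units; within the scatter) from compound 1 to compound 3 and a 1.1-fold lower number (0.05 log units; within the scatter) from compound 2 to compound 4, 1.7-fold (0.24 log units) apart, within the scatter of two such steps. Among the compounds shown here, this rests on only two cores and one exchange of halogens, and it shows neither that the step would hold on a further core nor why it occurs.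

Still open, from the compounds shown here alone, is whether bromo, methyl or trifluoromethyl in place of chloro would go further than chloro. Also open, going by these compounds, is whether an amine or a longer chain in place of phenyl or methoxymethyl would stay within the scatter of these numbers.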